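The source may report more compounds than this note shows. Statements on the series, on what has been measured and on what is new or still open speak of the compounds shown alone.

The measured compounds in a functional assay on HT-29 cells (Homo sapiens) for inhibition, read by MTT assay, with a stated time of 48 h; on this read-out lower numbers stand for stronger inhibition and higher numbers for weaker inhibition:

Compound 1, `Cc1ccc(NC(=S)NC(=O)c2ccc(OCc3ccc(C(F)(F)F)cc3)cc2)cc1-c1nc2ccccc2[nH]1`: 17600 nM
Compound 2, `Cc1ccc(NC(=S)NC(=O)c2ccc(OCc3ccc(Cl)c(Cl)c3)cc2)cc1-c1nc2ccccc2[nH]1`: 6270 nM
Compound 3, `O=C(NC(=S)Nc1ccc(Cl)c(-c2nc3ccccc3[nH]2)c1)c1ccc(OCc2ccc(C(F)(F)F)cc2)cc1`: 12900 nM

Compound 3 sits close to compound 1 in this assay, the two differing only by a 1.4-fold lower number from compound 1 to compound 3 (0.13 log units; within the scatter), which is within the scatter, so no order between them can be claimed. Against compound 2, however, compound 3 gives the higher number, and that gap lies beyond the scatter.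

The step from compound 3 to compound 4, `O=C(NC(=S)Nc1ccc(Cl)c(-c2nc3ccccc3[nH]2)c1)c1ccc(OCc2ccc(Cl)c(Cl)c2)cc1`, is 3,4-dichlorophenyl in place of 4-(trifluoromethyl)phenyl on a saturated chain carbon bound to an oxygen on an aromatic ring. The same exchange has already been made once within this set, between compound 1 and compound 2, where it gave a 2.8-fold lower number from compound 1 to compound 2 (0.45 log units; beyond the scatter) in this assay. For the measured compounds named here, compound 3 is tied to compound 1 by a change that stayed within the scatter, so the pair compound 1 and compound 2 is the closest guide available, and there is only that one guide. On that basis a lower number is expected for compound 4, with a step of about a 2.8-fold lower number from compound 3 to compound 4 (0.45 log units; beyond the scatter) in this assay from compound 3. Compound 4 is therefore estimated at 4600 nM in this assay, with a likely range from 2000 nM to 11000 nM.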

Compound 4, half-maximal inhibitory concentration: 4930 nM
Compound 4: middle estimate off by 1.1-fold (0.03 log units), on the low side; measured number inside the range.
By their numbers in this assay, from the lowest: compounds 4 and 2 (each within the scatter of the next); then compounds 3 and 1 (each within the scatter of the next).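

In this assay, placing 3,4-dichlorophenyl in place of 4-(trifluoromethyl)phenyl on a saturated chain carbon bound to an oxygen on an aromatic ring now gives a 2.6-fold lower number from compound 3 to compound 4 (0.42 log units; beyond the scatter). The change has thus been read on two cores rather than one, and its size carries over from the core with methyl to the core with chloro: the same change on two cores in this assay, a 2.8-fold lower number (0.45 log units; beyond the scatter) from compound 1 to compound 2 and a 2.6-fold lower number (0.42 log units; beyond the scatter) from compound 3 to compound 4, 1.1-fold (0.03 log units) apart, within the scatter of two such steps The exchange of chloro for methyl on an aromatic carbon, earlier read only with the 4-(trifluoromethyl)benzyl group, gives a 1.3-fold lower number from compound 2 to compound 4 (0.10 log units; within the scatter), so it too stays within the scatter with the 3,4-dichlorobenzyl group, and the two changes show no dependence on each other in these four compounds, none of which goes against this: the same change on two cores in this assay, a 1.4-fold lower number (0.13 log units; within the scatter) from compound 1 to compound 3 and a 1.3-fold lower number (0.10 log units; within the scatter) from compound 2 to compound 4, 1.1-fold (0.03 log units) apart, within the scatter of two such steps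

The exchange replaces one whole aryl group with another, so the compounds shown cannot tell whether either chloro alone accounts for the step, or how the loss of trifluoromethyl contributes to it. From the compounds shown here alone, it also remains open how an unsubstituted phenyl, a phenyl carrying a single chloro, or a pyridyl would read at this position.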